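Acetyl to Hydrogen in a Set That Stays Beyond the Limit

The compounds below may be only part of what the source reports. "The series", "measured", "known", "first", "only" and "open" are said of these compounds alone.

Compound 1 `CC(O)n1cnc2c(N)nc(I)nc21` and compound 2 `CC(=O)OC(C)n1cnc2c(N)nc(I)nc21` share one core and differ in a single place: hydrogen in place of acetyl on an oxygen on a saturated carbon. In a functional assay on WI-38 cells (Homo sapiens) for inhibition (a lower number here means a stronger inhibitor, a higher number a weaker inhibitor), compound 2 gives only a limit, > 500000 nM. Compound 1 also gives only a limit in this assay, > 500000 nM. The step that the two limits leave unreadable from compound 2 to compound 1 therefore cannot be read. Compound 3 `CC(=O)OC(C)n1cnc2c(S)nc(F)nc21` carries a different core; the difference between the two cores is not broken down here. In this assay compound 3 likewise gives only a limit, > 500000 nM. Across everything measured so far, (the limit of > 500000 nM in this assay, at which 3 of the 3 values shown sit), so no change in this set has yet produced a readable number.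

Compound 4 `CC(O)n1cnc2c(S)nc(F)nc21` has not been measured. It stands to compound 3 as compound 1 stands to compound 2: hydrogen in place of acetyl on an oxygen on a saturated carbon, the same change at the same place. For compound 4 a step of a number no higher from compound 3 to compound 4 (the limit leaves the size open) is expected, resting on a step that the two limits leave unreadable from compound 2 to compound 1 and on (the limit of > 500000 nM in this assay, at which 3 of the 3 values shown sit). Compound 4 is expected to give about 500000 nM in this assay, within 200000 nM to 2000000 nM, and most probably again only a limit.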

Compound 4, half-maximal inhibitory concentration: > 500000 nM
Compound 4: only a limit was reported; the forecaster's own chance of this, stated with the estimate: 90%; the middle value lies on the limit itself.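

Compound 4 gives only a limit in this assay, > 500000 nM. The change from compound 3 to compound 4 therefore cannot be read, and the set still holds no readable number: the limit of > 500000 nM in this assay, at which 4 of the 4 values shown sit. The compounds shown leave open whether replacing acetoxy with hydroxy changes inhibition at all, and how strongly any of these compounds inhibits in this assay.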